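A few compounds are considered here, and "the series" means these few. Any claim that something is new, unique, unknown or untested is made for them only; others in the source may bear on it.

Compound 2 `Cc1ccc(NC(=O)c2ccc(CNCCN(C)C)cc2)cc1Nc1nccc(-c2cccnc2)n1` is the starting point here. In an ADME assay on BaF3 cells (Mus musculus) for cytotoxicity, read by CellTiter-Glo and CCK-8 assay, with a stated time of 72 h (on this read-out higher numbers stand for weaker inhibition of growth and lower numbers for stronger inhibition of growth), compound 2 gives > 10000 nM, which is a limit of the assay and not a number. Its neighbour compound 1 `C=CC(=O)Nc1ccc(C(=O)Nc2ccc(C)c(Nc3nccc(-c4cccnc4)n3)c2)cc1` in this assay gives 5600 nM. Within the data shown here, the one measured step, an at least 1.7-fold higher number from compound 1 to compound 2 (0.25 log units; that floor lies within the scatter), rests on the limit of > 10000 nM in this assay, at which 1 of the 2 values shown sits, and so shows only a floor.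

Compound 3 `Cc1ccc(NC(=O)c2ccc(CN(CCN(C)C)C(=O)c3cccs3)cc2)cc1Nc1nccc(-c2cccnc2)n1` differs from compound 2 by (thiophen-2-yl)carbonyl in place of hydrogen on an amine nitrogen. No measured step touches this amine nitrogen, so the only guide is that compound 2 already sits at the limit in this assay and that nothing shown points to a stronger growth inhibition. The expected step is a step that the limit leaves unreadable from compound 2 to compound 3, that is, none beyond the scatter. Compound 3 is therefore estimated at 12000 nM, within a range from 4000 nM to 40000 nM, with a fair chance that only a limit is reported again.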

Compound 3, concentration for 50% growth inhibition: > 10000 nM
Compound 3 was reported as a limit; the forecaster's own chance of this, stated with the estimate: 65%; the middle value lies beyond the limit too.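

Compound 2 and compound 3 each stop at a limit of the assay and not at a number, so no step can be read between them: the limit of > 10000 nM in this assay, at which 2 of the 3 values shown sit.

From the compounds shown here alone, whether (thiophen-2-yl)carbonyl in place of hydrogen on an amine nitrogen changes growth inhibition at all in this assay stays open.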